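A few compounds are considered here, and "the series" means these few. Any claim that something is new, unique, unknown or untested is made for them only; others in the source may bear on it.

Measured compounds so far:
- compound 1 `O=S(=O)(Nc1ccc(-c2nc3ccccc3o2)cc1)c1cccs1` gives 63000 nM in an assay on cells for inhibition of HSP60/HSP10 (Homo sapiens), with a stated time of 60 min; on this read-out higher numbers stand for weaker inhibition and lower numbers for stronger inhibition
- compound 2 `O=S(=O)(Nc1ccc(-c2nc3ccccc3o2)cc1)c1ccc(O)cc1` gives 78000 nM in this assay
- compound 3 `O=S(=O)(Nc1ccc(-c2nc3ccccc3o2)cc1)c1ccc(C(F)(F)F)cc1` gives 50000 nM in this assay

All three compounds share the same core and differ only in the group on the sulfonyl sulfur. Compound 3 carries the lowest of the three numbers, but its gaps to compound 1 and compound 2 are both within the scatter, so no order among the three is claimed. The two single-point steps measured in the series, a 1.2-fold higher number from compound 1 to compound 2 (0.09 log units; within the scatter) and a 1.6-fold lower number from compound 2 to compound 3 (0.19 log units; within the scatter), are likewise within the scatter: exchanging the ring on the sulfonyl sulfur, or swapping hydroxy for trifluoromethyl on that ring, has not moved the read-out in any resolvable way.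

Compound 4 `O=S(=O)(Nc1ccc(-c2nc3ccccc3o2)cc1)c1ccc(Cl)cc1` continues the same line of variation: chloro in place of trifluoromethyl on an aromatic carbon. Among the compounds with values here, the only steps that bear on it are the two above, and both were within the scatter. The expectation for this assay is therefore a step from compound 3 to compound 4 of no resolvable size, a 1.1-fold higher number from compound 3 to compound 4 (0.04 log units; within the scatter), in neither direction with confidence. The estimate for compound 4 is 55000 nM, with a range from 25000 nM to 120000 nM.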

Compound 4, half-maximal inhibitory concentration: 61000 nM
Estimate against measurement, compound 4: 1.1-fold (0.04 log units) below; the measured number falls inside the stated range.
By their numbers in this assay, from the lowest: compounds 3, 4, 1 and 2 (each within the scatter of the next).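

In this assay, chloro in place of trifluoromethyl on this aromatic carbon, para to a large group, gives a 1.2-fold higher number from compound 3 to compound 4 (0.09 log units; within the scatter) even though the entering group has 1 heavy atom and the leaving group has 4, so this position has now taken a substituent that differs in size by this count without a resolvable shift in the read-out. The other comparisons agree, with a 1.3-fold lower number from compound 2 to compound 4 (0.11 log units; within the scatter) for chloro against hydroxy and a 1.0-fold lower number from compound 1 to compound 4 (0.01 log units; within the scatter) for 4-chlorophenyl against thiophen-2-yl on the sulfonyl sulfur, which leaves chloro, hydroxy, trifluoromethyl and the thiophen-2-yl ring indistinguishable in this assay and gives no order among compounds 1 to 4. No measurement at hand offers an explanation for why these groups read alike.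

Still open, on these data alone, is whether an amine or a carboxylic acid on this aromatic carbon, or a longer chain in place of the ring on the sulfonyl sulfur, would give a step beyond the scatter. Also open, as far as these compounds go, is whether a change within the shared core, rather than on the sulfonyl sulfur, would move the number in this assay in a resolvable way.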